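This account rests on a few compounds, and the source may have more. Where it says the series, first, only, none or still open, it means among the compounds named here.

Series notes. Compound 1 `c1cncc(-c2ccccc2OCC2=NCCN2)c1` and compound 2 `c1coc(-c2ccccc2OCC2=NCCN2)c1` share one core and differ only in the aromatic ring carried on it. In a functional assay for activation of Alpha-1B adrenergic receptor (Homo sapiens), read by calcium flux (a higher number here means that more compound is needed for the effect, a lower number that less compound is needed), compound 1 gives 79.4 nM. In this assay compound 2 gives 10 nM. Among the compounds with values here, of the two numbers measured so far, compound 1 stands highest, and the single measured step, a 7.9-fold lower number from compound 1 to compound 2 (0.90 log units; beyond the scatter), leads away from it. Compound 3 `c1ccc(-c2ccoc2)c(OCC2=NCCN2)c1` has not yet been measured in this assay. It differs from compound 1 as follows: furan-3-yl in place of pyridin-3-yl on an aromatic carbon. Within the data shown here, the one step that bears on this change is a 7.9-fold lower number from compound 1 to compound 2 (0.90 log units; beyond the scatter), where furan-2-yl took the place of pyridin-3-yl on an aromatic carbon; furan-3-yl is a different group, so the same size of step cannot simply be assumed, though the direction is the best guide available. For compound 3 the expected step is a 4.0-fold lower number from compound 1 to compound 3 (0.60 log units; beyond the scatter). This means a lower number than compound 1 shows, and most likely a smaller move than compound 2 made. The estimate for compound 3 in this assay is 20 nM, with a range from 6 nM to 63 nM.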

Compound 3, half-maximal effective concentration: 5.01 nM
For compound 3 the middle estimate is 4.0-fold (0.60 log units) above the measured one; the whole stated range lies above it.
By their numbers in this assay, from the lowest: compounds 3 and 2 (each within the scatter of the next); then compound 1.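

In this assay, the aromatic carbon ortho to a group of 7 heavy atoms now carries a second five-membered aromatic ring in place of pyridin-3-yl, and furan-3-yl gives a 16-fold lower number from compound 1 to compound 3 (1.20 log units; beyond the scatter); the move seen with furan-2-yl is therefore not tied to a single furan attachment. The exchange of one furan for the other gives a 2.0-fold lower number from compound 2 to compound 3 (0.30 log units; within the scatter), so the point of attachment of the furan makes no readable difference at this position, while both furans remain clearly apart from the pyridin-3-yl of compound 1. Nothing at hand accounts for the separation between the furans and pyridin-3-yl.

The compounds shown leave open whether the separation follows the ring oxygen, the five-membered ring size or the loss of the ring nitrogen, a question that a thiophene, a pyrrole or a plain phenyl ring at the same carbon would bear on. As far as these compounds go, it also remains open how far the position tolerates substitution on the furan itself, such as a methyl group or a chlorine.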